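The source may hold more compounds than are shown below. What is called first, only, known or untested is meant among the compounds shown, and "the series" means these compounds.

Measured in a functional assay on SK-BR-3 cells (Homo sapiens) for antiproliferative activity, read by MTT assay, with a stated time of 72 h; on this read-out higher numbers stand for weaker inhibition and lower numbers for stronger inhibition:
Compound 1 `C/C=C1/[C@H](O[C@@H]2O[C@H](CO)[C@@H](O)[C@H](O)[C@H]2O)OC=C(C(=O)OC)[C@H]1CC(=O)NCCC`: > 20000 nM (a limit of the assay, not a number)
Compound 2 `C/C=C1/[C@H](O[C@@H]2O[C@H](CO)[C@@H](O)[C@H](O)[C@H]2O)OC=C(C(=O)OC)[C@H]1CC(=O)OCCC1CCCCC1`: 2000 nM

Among the measured compounds shown here, compound 2 holds the only true number so far, 2000 nM. The other value is a limit, as the limit of > 20000 nM in this assay, at which 1 of the 2 values shown sits, records.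

Compound 3 `C#CCOC(=O)C[C@@H]1C(C(=O)OC)=CO[C@@H](O[C@@H]2O[C@H](CO)[C@@H](O)[C@H](O)[C@H]2O)/C1=C/C` differs from compound 2 by ethynyl in place of cyclohexylmethyl on a saturated chain carbon bound to an oxygen next to a carbonyl group.

For the measured compounds named here, one measured step bears on this change, an at least 10-fold lower number from compound 1 to compound 2 (1.00 log units; beyond the scatter), which lies beyond the scatter and puts 2-cyclohexylethoxy in place of propylamino on a carbonyl carbon. It alters the link to the carbonyl as well as the chain, so it is only a partial guide. Compound 3 keeps the oxygen of compound 2 but, like compound 1, has no ring in that chain. On the evidence of an at least 10-fold lower number from compound 1 to compound 2 (1.00 log units; beyond the scatter), a modest move towards weaker inhibition is expected in this assay, and it may not clear the scatter by much. The expected change is a 3.5-fold higher number from compound 2 to compound 3 (0.54 log units; beyond the scatter). For compound 3 the estimate is 7000 nM, with an expected range of 2500 nM to 20000 nM.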

Compound 3, half-maximal inhibitory concentration: > 15000 nM
Compound 3: a limit, no number; the forecaster's own chance of this, stated with the estimate: 35%; at least 2.1-fold (0.33 log units) between middle value and limit.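

Replacing cyclohexylmethyl with ethynyl on a saturated chain carbon bound to an oxygen next to a carbonyl group gives, in this assay, an at least 7.5-fold higher number from compound 2 to compound 3 (0.87 log units; beyond the scatter). The earlier step changed the link to the carbonyl and the chain together, whereas this one changes the chain alone, so keeping the oxygen of compound 2 does not by itself keep its activity once the cyclohexyl ring and most of the chain are gone. The entry for compound 3 is a limit and not a number, so the true size of this step stays unknown beyond the least it can be: the limit of > 15000 nM in this assay, at which 1 of the 3 values shown sits.

On these data alone, the step from compound 1 to compound 3 cannot be read, with a limit at each end of it: the limit of > 20000 nM in this assay, at which 1 of the 3 values shown sits. Whether the activity of compound 2 rests on the cyclohexyl ring or simply on the length of the chain stays open, and a straight hexyl chain or a 2-phenylethyl group on the same oxygen would begin to separate the two.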